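The source may report more compounds than this note shows. Statements on the series, on what has been measured and on what is new or still open speak of the compounds shown alone.

Measured compounds:
compound 1 `O=C(/C=C/c1ccc(OCc2cn(Cc3cccc(Br)c3)nn2)cc1)c1ccc(Br)cc1` gives 25%
compound 2 `O=C(/C=C/c1ccc(OCc2cn(Cc3ccccc3)nn2)cc1)c1ccc([N+](=O)[O-])cc1` is reported as "not active" (no number reported)
compound 3 `O=C(/C=C/c1ccc(OCc2cn(Cc3ccccc3Br)nn2)cc1)c1ccc([N+](=O)[O-])cc1` gives 32%

These three compounds share one core and differ in the benzyl group on the triazole and in the substituent on the aryl ketone. They were tested in a functional assay on HepG2 cells (Homo sapiens) for inhibition, read by MTT assay, with a stated time of 48 h, tested at 10 uM; on this read-out higher numbers stand for more inhibition of growth at the one concentration tested and lower numbers for less inhibition of growth. For the measured compounds named here, of the two numbers reported, the one for compound 3 is the higher, but its gap to compound 1 lies within the scatter, so the two cannot be told apart on this read-out. Compound 2 carries a plain benzyl group and is reported only as not active, without a number.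

Compound 4 `O=C(/C=C/c1ccc(OCc2cn(Cc3cccc(Br)c3)nn2)cc1)c1ccc([N+](=O)[O-])cc1` is the next compound to be tested in this assay. It differs from compound 3 in one place: 3-bromophenyl in place of 2-bromophenyl on a saturated chain carbon bound to an aromatic nitrogen. Going by the values given here, no step between two measured compounds isolates this change. Compound 4 carries the same 3-bromobenzyl group as compound 1, and compound 1 gives 25%, a value that sits within the scatter of compound 3, so no step beyond the scatter is expected. For compound 4 a value of 28% is estimated, with a range from 12% to 42%. The expected step of a number 4 percentage points lower from compound 3 to compound 4 (within the scatter) is therefore small.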

Compound 4, percent growth inhibition at one concentration: 13%
Estimate against measurement, compound 4: 15 percentage points above; the range from low to high includes it.
By their numbers in this assay, from the lowest: compound 4; then compounds 1 and 3 (each within the scatter of the next).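

With the nitro-substituted aryl ketone held fixed, 3-bromophenyl in place of 2-bromophenyl on a saturated chain carbon bound to an aromatic nitrogen gives a number 19 percentage points lower from compound 3 to compound 4 (beyond the scatter) in this assay, so two groups with the same atoms can be told apart at this place. With the 3-bromobenzyl group held fixed, nitro in place of bromo on an aromatic carbon gives a number 12 percentage points lower from compound 1 to compound 4 (beyond the scatter) on the same read-out, the first numerical view of a change at the aryl ketone. Nothing given here bears on why either step arises.

As far as these compounds go, it remains open whether nitro in place of bromo gives a similar step when the 2-bromobenzyl group is present. From the compounds shown here alone, how an amine or a carboxylic acid in place of the bromine on the benzyl group would read in this assay also remains open.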